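The source may hold more compounds than are shown below. What is called first, only, known or untested is meant among the compounds shown, and "the series" means these compounds.

Three compounds have been measured in an assay on Sf9 cells for inhibition of protein deacetylase HDAC6 (Homo sapiens), read by fluorescence, with a stated time of 40 min, tested at 100 nM; on this read-out higher numbers stand for more inhibition at the one concentration tested (going by the name of the read-out) and lower numbers for less inhibition:
compound 1 `Cc1ccc(-c2nc(CNc3ccc(C(=O)NO)cc3)n(-c3ccccc3)n2)o1`, 60.7%;
compound 2 `O=C(NO)c1ccc(NCc2nc(-c3cccc(Cl)c3)nn2-c2ccccc2)cc1`, 61.2%;
compound 3 `O=C(NO)c1ccc(NCc2nc(-c3ccc(C(F)(F)F)cc3)nn2-c2ccccc2)cc1`, 41.6%.

Compound 3 stands lowest of the three. The step of a number 19.1 percentage points lower from compound 1 to compound 3 (beyond the scatter) and the step of a number 19.6 percentage points lower from compound 2 to compound 3 (beyond the scatter) both lie beyond the scatter, while a number 0.5 percentage points higher from compound 1 to compound 2 (within the scatter) lies within it. Compound 4 `O=C(NO)c1ccc(NCc2nc(-c3ccccc3)nn2-c2ccccc2)cc1` differs from compound 3 by hydrogen in place of trifluoromethyl on an aromatic carbon. Both steps into compound 3 bear on this change: each puts 4-(trifluoromethyl)phenyl in place of another aromatic group and lowers the read-out by a modest amount. Going by the values given here, removing trifluoromethyl may recover part of that loss, though no measured step shows phenyl itself. Compound 4 is therefore expected to rise by a number 12.4 percentage points higher from compound 3 to compound 4 (beyond the scatter). The estimate for compound 4 is 54%, with an expected range from 40% to 68%.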

Compound 4, a percentage reported as inhibition, at one concentration (the size of the read-out at that concentration, not a potency): 72.6%
Compound 4: middle estimate off by 18.6 percentage points, on the low side; the measured number lies above the stated range.
By their numbers in this assay, from the lowest: compound 3; then compounds 1 and 2 (each within the scatter of the next); then compound 4.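

In this assay, the unsubstituted phenyl of compound 4 gives the highest number of the four, and every step into it lies beyond the scatter: a number 31 percentage points higher from compound 3 to compound 4 (beyond the scatter), a number 11.4 percentage points higher from compound 2 to compound 4 (beyond the scatter) and a number 11.9 percentage points higher from compound 1 to compound 4 (beyond the scatter). Among these compounds, then, neither trifluoromethyl nor chloro on the phenyl adds to the read-out, and the step from trifluoromethyl to hydrogen is the large one. Nothing available accounts for these steps. Open, as far as these compounds go, is whether a methoxy group or an amine on this aromatic carbon would hold the read-out, and whether a cyclohexyl group could replace the phenyl.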